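A few compounds are considered here, and "the series" means these few. Any claim that something is new, unique, unknown or untested is made for them only; others in the source may bear on it.

The series shares one core, seen in compound 1 `O=C(Nc1ccc(Cl)cc1)Nc1ccc(Oc2ccc(-c3nccs3)cc2)cc1`, compound 2 `O=C(Nc1ccccc1)Nc1ccc(Oc2ccc(-c3nccs3)cc2)cc1` and compound 3 `Cc1ccc(NC(=O)Nc2ccc(Oc3ccc(-c4nccs4)cc3)cc2)cc1`, and differs only in the aryl group on the outer urea nitrogen. In a functional assay on A549 cells (Homo sapiens) for inhibition, read by MTT assay and WST assay, with a stated time of 72 h, tested at 10 uM (on this read-out higher numbers stand for more inhibition of growth at the one concentration tested and lower numbers for less inhibition of growth), compound 1 gives 17.7%, while for compound 2 the result is "not determined" (no result reported). In this assay, among the compounds with values here, compound 3 gives 15.6%, and the single step measured so far, a number 2.1 percentage points lower from compound 1 to compound 3 (within the scatter), places compound 3 alongside compound 1 rather than apart from it; with only these two numbers, compound 3 sits with the one other measured compound.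

Compound 4 `O=C(Nc1ccc(Oc2ccc(-c3nccs3)cc2)cc1)Nc1ccc(F)c(Cl)c1` carries 3-chloro-4-fluorophenyl in place of 4-methylphenyl on an amide-type nitrogen. Within the data shown here, the only measured step that bears on this change is the exchange of chloro for methyl between compound 1 and compound 3, which gave a number 2.1 percentage points lower from compound 1 to compound 3 (within the scatter) and stayed within the scatter. Among the measured compounds shown here, no measured step covers the additional fluorine or the 3-chloro-4-fluorophenyl arrangement itself, so the expectation rests on that one small step. Compound 4 is therefore expected to show no change beyond the scatter in this assay, a step of about a number 0.4 percentage points higher from compound 3 to compound 4 (within the scatter). Compound 4 is estimated to give 16% in this assay, with a range from 4% to 32%.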

Compound 4, percent growth inhibition at one concentration: 37.3%
The estimate for compound 4 lay 21.3 percentage points below the measured number, and the stated range ends below it.
By their numbers in this assay, from the lowest: compounds 3 and 1 (each within the scatter of the next); then compound 4.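

The earlier pair showed only that 4-chlorophenyl and 4-methylphenyl on the outer urea nitrogen could not be told apart, so this position might have seemed insensitive to the aryl group. Compound 4 shows otherwise: in this assay there is a number 21.7 percentage points higher from compound 3 to compound 4 (beyond the scatter) and also a number 19.6 percentage points higher from compound 1 to compound 4 (beyond the scatter), so 3-chloro-4-fluorophenyl stands apart from both of the other aryl groups, by a modest margin in each case. Nothing given here accounts for this gain.

Steps to compound 2 cannot be read, so the effect of any substituent relative to the bare phenyl stays open, and the compounds shown do not separate the contribution of the fluorine from that of the altered chlorine placement, as 3-chlorophenyl and 4-fluorophenyl are not among them. On these data alone, it also remains open whether the gain extends to other groups on this ring, such as a methoxy group, a trifluoromethyl group or a carboxylic acid, and how it would appear beyond the one concentration tested.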